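Removing the Bromo Group from Compound 3

The source may hold more compounds than are shown below. What is called first, only, known or untested is meant among the compounds shown, and "the series" means these compounds.

Measured in a functional assay on A549 cells (Homo sapiens) for cytotoxicity; a lower number here means a stronger inhibitor, a higher number a weaker inhibitor:
- compound 1 (`Cc1ccc(S(=O)(=O)N2CC(c3ccccc3)NC2=O)cc1`) : 12500 nM
- compound 2 (`Cc1ccc(C2CNC(=O)N2S(=O)(=O)c2ccccc2)cc1`) : 157000 nM
- compound 3 (`O=C1NCC(c2ccc(Br)cc2)N1S(=O)(=O)c1ccc2c(c1)CCC2`) : > 237000 nM

Compound 3 has no number, only a reading at a limit (the limit of > 237000 nM in this assay, at which 1 of the 3 values shown sits). Compound 4 (`O=C1NCC(c2ccccc2)N1S(=O)(=O)c1ccc2c(c1)CCC2`) has not yet been measured. It differs from compound 3 by hydrogen in place of bromo on an aromatic carbon, para to a large group, the change from 4-bromophenyl to phenyl (hydrogen in place of bromo on an aromatic carbon). Within the data shown here, no measured pair of compounds shows this change, so any expectation of its size is loose. Compound 1 also carries a phenyl and reads 12500 nM in this assay, so a sizeable move towards stronger inhibition is expected. A reading at the limit nevertheless remains possible for compound 4. The expected change is an at least 5.2-fold lower number from compound 3 to compound 4 (0.72 log units; beyond the scatter). For compound 4 the estimated value is 45000 nM, with an expected range from 9000 nM to 230000 nM.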

Compound 4, half-maximal inhibitory concentration: 58500 nM
The estimate for compound 4 lay 1.3-fold (0.11 log units) below the measured number, and the stated range covers the measured number.
By their numbers in this assay, from the lowest: compound 1; then compound 4; then compound 2. At a limit, above all of these: compound 3.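

Taking the bromo off this aromatic carbon gives the first reading of this change in this assay, and it is a real move: an at least 4.0-fold lower number from compound 3 to compound 4 (0.60 log units; beyond the scatter). Among these compounds, the 4-bromophenyl to phenyl change thus lifts the compound with this sulfonyl group off the limit and gives it a measurable number, which the earlier compounds could not show for this position. Compound 3 has only a limit, so the step gives a minimum size and not an exact one: the limit of > 237000 nM in this assay, at which 1 of the 4 values shown sits.

Going by these compounds, the full size of the step stays open, and one pair cannot show whether it would hold on another core. Also open, on these data alone, is how this assay would read with an amine or a carboxylic acid at this position in place of the bromo.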